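This account rests on a few compounds, and the source may have more. Where it says the series, first, only, none or still open, it means among the compounds named here.

In a functional assay on P388 cells (Mus musculus) for inhibition (a lower number here means a stronger inhibitor, a higher number a weaker inhibitor), compound 3 `COc1ccc(/C=C/c2ccc3ccccc3c2)cc1` gives only a limit, > 5000 nM, and not a number. Compound 1 `CC(=O)Oc1ccc(/C=C/c2ccc3ccccc3c2)cc1` likewise gives only a limit, > 5000 nM. Compound 2 `Oc1ccc(/C=C/c2ccc3ccccc3c2)cc1` gives a true number, 4060 nM. Compound 4 `COc1ccc(/C=C/c2ccc3ccccc3c2)cc1N` differs from compound 3 by one change, amino in place of hydrogen on an aromatic carbon, ortho to a methoxy group. The measured steps bear on this only loosely, as they alter the group on the oxygen, not this ring carbon: an at least 1.2-fold lower number from compound 1 to compound 2 (0.09 log units; that floor lies within the scatter), and an at least 1.2-fold higher number from compound 2 to compound 3 (0.09 log units; that floor lies within the scatter). A modest move towards a lower number is expected, though with low confidence, and the expected step is an at least 2.5-fold lower number from compound 3 to compound 4 (0.39 log units; beyond the scatter). For compound 4 the estimate is 2000 nM, with an expected range of 300 nM to 6000 nM.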

Compound 4, half-maximal inhibitory concentration: > 5000 nM
Compound 4: no number, only a limit (the forecaster's own chance of this, stated with the estimate: 35%); at least 2.5-fold (0.39 log units) between middle value and limit.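

Compound 3 and compound 4 each give only a limit in this assay, so the step between them cannot be read: the limit of > 5000 nM in this assay, at which 3 of the 4 values shown sit. The compounds shown leave open whether amino in place of hydrogen changes inhibition at all.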